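Permeability Across Three Amide Variants and a Fourth

A few compounds are considered here, and "the series" means these few. Any claim that something is new, unique, unknown or untested is made for them only; others in the source may bear on it.

Compound 1, `C=C(C)C(=O)N1CCC(CN(C2Cc3cc(C#N)ccc3N(Cc3cncn3C)C2)S(=O)(=O)c2ccccn2)CC1`: 0.5 10^-6 cm/s
Compound 2, `Cn1cncc1CN1CC(N(CC2CCN(C(=O)Nc3ccc(Br)cc3)CC2)S(=O)(=O)c2ccccn2)Cc2cc(C#N)ccc21`: 0.6 10^-6 cm/s
Compound 3, `Cn1cncc1CN1CC(N(CC2CCN(C(=O)c3ccco3)CC2)S(=O)(=O)c2ccccn2)Cc2cc(C#N)ccc21`: 0.5 10^-6 cm/s

In an ADME assay on Caco-2 cells (Homo sapiens) for permeability, in the apical to basolateral direction (on this read-out higher numbers stand for higher permeability and lower numbers for lower permeability), compound 2 holds the highest of the three numbers, yet its steps to the other two stay within the scatter: a 1.2-fold higher number from compound 1 to compound 2 (0.08 log units; within the scatter) and a 1.2-fold lower number from compound 2 to compound 3 (0.08 log units; within the scatter). Compound 4, `Cn1cncc1CN1CC(N(CC2CCN(C(=O)CC(F)(F)F)CC2)S(=O)(=O)c2ccccn2)Cc2cc(C#N)ccc21`, carries the change (2,2,2-trifluoroethyl in place of (4-bromophenyl)amino on a carbonyl carbon). The two measured steps at that same carbonyl carbon bear on this one, and both fell within the scatter, so a fourth substituent at that position is expected to leave the number in this assay essentially where compound 2 sits, with no direction beyond the scatter. Compound 4 is therefore estimated at 0.6 10^-6 cm/s, with a range from 0.3 10^-6 cm/s to 1.2 10^-6 cm/s. That estimate means an expected step of no change at the digits printed from compound 2 to compound 4 (within the scatter).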

Compound 4, apparent permeability: 0.5 10^-6 cm/s
Compound 4: the middle estimate sits 1.2-fold (0.08 log units) above what was measured; measured number inside the range.
By their numbers in this assay, from the lowest: compounds 1, 3, 4 and 2 (each within the scatter of the next).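

In this assay, 2,2,2-trifluoroethyl on this carbonyl carbon takes the place of (4-bromophenyl)amino, giving up the aromatic ring and the hydrogen-bond donor, with a 1.2-fold lower number from compound 2 to compound 4 (0.08 log units; within the scatter). The other two steps read no change at the digits printed from compound 3 to compound 4 (within the scatter) and no change at the digits printed from compound 1 to compound 4 (within the scatter), so all four groups at this position stand within the scatter of one another. No measurement at hand offers an explanation for this. The compounds shown leave open whether a carboxylic acid or a longer chain at this carbonyl carbon would give a step beyond the scatter.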